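Nitro in Place of Trifluoromethyl: What Is Expected

A few compounds are considered here, and "the series" means these few. Any claim that something is new, unique, unknown or untested is made for them only; others in the source may bear on it.

In a functional assay on A549 cells (Homo sapiens) for antiproliferative activity, read by MTT assay, with a stated time of 72 h (a lower number here means a stronger inhibitor, a higher number a weaker inhibitor), compound 1 `FC(F)(F)c1ccc(COc2ccccc2Nc2ncnc3cc4c(cc23)OCCOCCO4)cc1` returns only a limit, > 100000 nM. Among the measured compounds shown here, compound 2 `FC(F)(F)c1ccc(COc2ccc(Nc3ncnc4cc5c(cc34)OCCOCCOCCOCCO5)cc2)cc1` is the sole member of the pair with a numerical result, giving 8560 nM in this assay. Compound 3 `O=[N+]([O-])c1ccc(COc2ccc(Nc3ncnc4cc5c(cc34)OCCOCCOCCOCCO5)cc2)cc1` differs from compound 2 by nitro in place of trifluoromethyl on an aromatic carbon. For the measured compounds named here, no measured pair isolates this change, so the shift in this assay is expected to be small, within the usual scatter, and in no firm direction. The expected step is a 1.2-fold lower number from compound 2 to compound 3 (0.09 log units; within the scatter). On that basis compound 3 is estimated at 7000 nM in this assay, with a range from 2500 nM to 25000 nM.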

Compound 3, half-maximal inhibitory concentration: > 100000 nM
Compound 3 ended at the assay's limit; the forecaster's own chance of this, stated with the estimate: 15%; middle value at least 14-fold (1.15 log units) away from the limit.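

Nitro in place of trifluoromethyl on this aromatic carbon is the first change here that can be read in one place, and in this assay it gives an at least 11-fold higher number from compound 2 to compound 3 (1.06 log units; beyond the scatter). The measurable result of compound 2 therefore does not carry over to compound 3, so the group at this position matters in this series. The value of compound 3 is a limit, so the step gives only a lower bound on the change: the limit of > 100000 nM in this assay, at which 2 of the 3 values shown sit.

The compounds shown leave open whether a nitrile, an amine or a carboxylic acid at this position would keep a numerical result. They also leave open how the same change would read with the shorter chain of compound 1.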